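Methoxy for Chloro: an Expectation for Compound 4

The source may report more compounds than this note shows. Statements on the series, on what has been measured and on what is new or still open speak of the compounds shown alone.

Compound 1 `Clc1ccc2[nH]c(-c3cn(-c4ccccc4)nc3-c3ccccc3)nc2c1` reaches only the limit > 50000 nM in an ADME assay on HaCaT cells (Homo sapiens) for cytotoxicity, read by MTT assay, with a stated time of 48 h; on this read-out higher numbers stand for weaker inhibition and lower numbers for stronger inhibition.
Compound 2 `COc1ccc2[nH]c(-c3cn(-c4ccccc4)nc3-c3ccccc3)nc2c1` likewise gives a limit, > 50000 nM, in this assay.
Compound 3 `Fc1ccc2[nH]c(-c3cn(-c4ccccc4)nc3-c3ccc(Cl)cc3)nc2c1` also stops at a limit, > 50000 nM, in this assay.

For the measured compounds named here, the one step between measured compounds that differ in a single place runs from compound 1 to compound 2: methoxy in place of chloro on an aromatic carbon. Its size is a step that the two limits leave unreadable from compound 1 to compound 2, since both ends are limits and neither gives a number. The cores of compound 1 and compound 3 differ in more than one place, and that difference is not broken down here.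

Compound 4 `COc1ccc(-c2nn(-c3ccccc3)cc2-c2nc3cc(F)ccc3[nH]2)cc1` has not yet been measured. It differs from compound 3 by methoxy in place of chloro on an aromatic carbon. Going by the values given here, this is the same kind of change as the one from compound 1 to compound 2, but not the same: there the methoxy entered on an aromatic carbon of a six-membered aromatic ring of carbon only, part of a fused or bridged system of two rings, meta to a fused ring and para to a fused ring, whereas here it enters on a six-membered aromatic ring of carbon only, para to a large group.

Among the compounds with values here, all values so far sit at one point: the limit of > 50000 nM in this assay, at which 3 of the 3 values shown sit. On that basis, and because the earlier step that the two limits leave unreadable from compound 1 to compound 2 moved nothing readable, compound 4 is expected to show a step that the limit leaves unreadable from compound 3 to compound 4 in this assay. Compound 4 is estimated at 60000 nM, between 20000 nM and 200000 nM, most likely reported again only as a limit.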

Compound 4, half-maximal inhibitory concentration: > 50000 nM
Compound 4: only a limit was reported; the forecaster's own chance of this, stated with the estimate: 80%; the middle value does not contradict the limit.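

For the compounds shown here, compound 3 and compound 4 are both reported only as limits, so the change from 4-chlorophenyl to 4-methoxyphenyl gives no step that can be read. The four compounds stop at a single point: the limit of > 50000 nM in this assay, at which 4 of the 4 values shown sit.

The compounds shown leave open how large the effect of methoxy in place of chloro is, and whether any change to the shared core would give a readable value in this assay.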